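Formyl in place of methyl on the anilino ring

The compounds below may be only part of what the source reports. "The series", "measured", "known", "first", "only" and "open" are said of these compounds alone.

Of the compounds shown here, two have been measured in an assay on Sf9 cells for inhibition of 1-acyl-sn-glycerol-3-phosphate acyltransferase beta (Homo sapiens); a higher number here means a weaker inhibitor, a lower number a stronger inhibitor. Compound 1 `COc1ccc(Cl)cc1-c1cc(N)cc(Nc2ccc(C)cc2)n1` gives 29000 nM in this assay. Compound 2 `COc1ccc(Cl)cc1-c1cc(N)nc(Nc2ccc(C)cc2)c1` gives 240 nM in this assay. Of the two numbers, that of compound 2 is the lower one; the gap to compound 1 lies well beyond the scatter of repeated measurements, so compound 2 is the stronger inhibitor of the pair. Among the measured compounds shown here, the two structures differ in more than one place, so no single step between them can be described.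

Compound 3 `COc1ccc(Cl)cc1-c1cc(N)nc(Nc2ccc(C=O)cc2)c1` has not yet been measured in this assay. It differs from compound 2 in one place: formyl in place of methyl on an aromatic carbon. For the measured compounds named here, no measured pair shows this kind of change, so there is no step to lean on. The expected step from compound 2 to compound 3 is a 2.1-fold higher number from compound 2 to compound 3 (0.32 log units; beyond the scatter), a small move toward a higher number that may well stay within the scatter. Compound 3 is therefore estimated at 500 nM in this assay, with a range from 150 nM to 2500 nM.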

Compound 3, half-maximal inhibitory concentration: 260 nM
Compound 3: the middle estimate sits 1.9-fold (0.28 log units) above what was measured; the measured number falls inside the stated range.
By their numbers in this assay, from the lowest: compounds 2 and 3 (each within the scatter of the next); then compound 1.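

Methyl and formyl on this ring, at the carbon para to a large group, give the first one-place step available in this assay, and it reads as a 1.1-fold higher number from compound 2 to compound 3 (0.03 log units; within the scatter). Among the compounds shown here, earlier, the only measured pair differed in more than one place, so it said nothing about this position; now it is clear that, on the core of compound 2, this assay does not separate the two groups, even though formyl carries an oxygen and a hydrogen-bond acceptor that methyl lacks. No measurement offered here explains why the two groups read alike.

A single pair cannot show how far this holds at the same position, and an amine, a carboxylic acid, a chloro group or a longer chain such as propyl could each read quite differently there. From the compounds shown here alone, it also remains open whether the same change would read alike on the core of compound 1, which gives 29000 nM with methyl in this place.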